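Replacing the carboxy of compound 2 with dimethylcarbamoyl

The source may hold more compounds than are shown below. What is called first, only, known or untested is meant among the compounds shown, and "the series" means these compounds.

Measured in an ADME assay on J774 cells (Mus musculus) for cytotoxicity; on this read-out lower numbers stand for an effect already at smaller amounts and higher numbers for an effect only at larger amounts of compound:
Compound 1 `CCCCc1cc2c(=O)c(CC)c[nH]c2cc1OCCOc1ccccc1`: 360 nM
Compound 2 `CCCCc1cc2c(=O)c(C(=O)O)c[nH]c2cc1OCCOc1ccccc1`: > 20000 nM

The entry for compound 2 is a limit and not a number: > 20000 nM. It sits at the limit of > 20000 nM in this assay, at which 1 of the 2 values shown sits.

The next structure is compound 3 `CCCCc1cc2c(=O)c(C(=O)N(C)C)c[nH]c2cc1OCCOc1ccccc1`, which differs from compound 2 as follows: dimethylamino in place of hydroxy on a carbonyl carbon. In words, dimethylamino stands in place of hydroxy on a carbonyl carbon, so carboxy becomes dimethylcarbamoyl.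

For the measured compounds named here, one measured step bears on this change, an at least 55-fold higher number from compound 1 to compound 2 (1.74 log units; beyond the scatter). That step is large and lies beyond the scatter, and it is the step that brings in the carboxy which compound 3 no longer carries. Going by the values given here, no measured compound holds a dimethylcarbamoyl, so this reading is uncertain.

A large step to a lower number is therefore expected in this assay, going part of the way back towards compound 1 at 360 nM. The expected change is an at least 5.0-fold lower number from compound 2 to compound 3 (0.69 log units; beyond the scatter). For compound 3 the estimated value is 4000 nM, with an expected range of 700 nM to 20000 nM.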

Compound 3, half-maximal effective concentration: 15300 nM
The estimate for compound 3 lay 3.8-fold (0.58 log units) below the measured number; measured number inside the range.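

In this assay, the high number turns out not to be confined to the carboxy: compound 3 has no carboxy and still stands far from compound 1, with a 43-fold higher number from compound 1 to compound 3 (1.63 log units; beyond the scatter). Exchanging hydroxy for dimethylamino on the carbonyl carbon gives an at least 1.3-fold lower number from compound 2 to compound 3 (0.11 log units; that floor lies within the scatter), so the shift that can be shown for this change is no greater than the usual scatter. The entry for compound 2 is a limit and not a number, so the true size of that step stays open: the limit of > 20000 nM in this assay, at which 1 of the 3 values shown sits.

Whether the high number goes with a carbonyl on this aromatic carbon or with any replacement of ethyl remains open, as ethyl, carboxy and dimethylcarbamoyl are the only groups shown there. A methyl ester would test the carbonyl reading and a longer chain such as propyl the other, while the three compounds shown cannot separate the two.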